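Replacing the 3-hydroxyphenyl group of compound 3

A few compounds are considered here, and "the series" means these few. Any claim that something is new, unique, unknown or untested is made for them only; others in the source may bear on it.

Compound 1 `O=C(CSc1nc2ccccc2[nH]1)Nc1ccc2nc(NC(=O)c3ccc(C(F)(F)F)cc3)sc2c1`: 7110 nM
Compound 2 `O=C(CSc1cccc(O)c1)Nc1ccc2nc(NC(=O)c3ccccc3)sc2c1`: > 100000 nM (a limit)
Compound 3 `O=C(CSc1cccc(O)c1)Nc1ccc2nc(NC(=O)c3ccc(F)cc3)sc2c1`: 5120 nM

In a functional assay on U2OS cells (Homo sapiens) for antiproliferative activity, read by MTT assay, with a stated time of 72 h (on this read-out higher numbers stand for weaker inhibition and lower numbers for stronger inhibition), compound 3 gives 5120 nM and compound 1 gives 7110 nM, two values within the scatter of each other. Compound 2 reaches only a limit, > 100000 nM.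

In compound 4 `O=C(CSc1ccc(Cl)cc1)Nc1ccc2nc(NC(=O)c3ccc(F)cc3)sc2c1`, 4-chlorophenyl stands in place of 3-hydroxyphenyl on a sulfur: 4-chlorophenyl in place of 3-hydroxyphenyl on a sulfur. Within the data shown here, the one measured step, an at least 19-fold lower number from compound 2 to compound 3 (1.29 log units; beyond the scatter), is large, but it is a fluoro in place of hydrogen on an aromatic carbon and not a change on the sulfur. It therefore gives no direction for compound 4, though it does show that one change can move this family far, so a wide range is warranted. The expectation in this assay is a modest step of open direction, starting from compound 3 at 5120 nM. The expected step is a 1.0-fold lower number from compound 3 to compound 4 (0.01 log units; within the scatter). For compound 4 the estimated value is 5000 nM, with an expected range from 1200 nM to 25000 nM.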

Compound 4, half-maximal inhibitory concentration: 2510 nM
For compound 4 the middle estimate is 2.0-fold (0.30 log units) above the measured one; measured number inside the range.
By their numbers in this assay, from the lowest: compound 4; then compounds 3 and 1 (each within the scatter of the next). At a limit, above all of these: compound 2.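

On the sulfur, the move to 4-chlorophenyl gives a 2.0-fold lower number from compound 3 to compound 4 (0.31 log units; beyond the scatter) in this assay, and this is the first step shown at this place, since the earlier large step lay on the other aromatic ring. The pair shows that the sulfur substituent can itself shift the value, if only modestly, and that the hydrogen-bond donor counted on 3-hydroxyphenyl is not needed to reach the level of compound 4, which carries none. No measurement shown here accounts for the step.

The change removes the hydroxy group and brings in chlorine at a different ring position in a single move, so the two cannot be separated. Going by these compounds, whether 3-chlorophenyl or 4-hydroxyphenyl on the sulfur would follow compound 4 or compound 3 stays open, as does the effect of a saturated cyclohexyl there.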